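Swapping the Anilide Aryl Group of a Weak Cytotoxic Hit

This account rests on a few compounds, and the source may have more. Where it says the series, first, only, none or still open, it means among the compounds named here.

Compound 1 `COc1ccc(NC(=O)CN2CCN(c3nnc(Cc4ccncc4)c4ccccc34)CC2)cc1OC`: 26500 nM
Compound 2 `Cc1ccc(F)cc1NC(=O)CN1CCN(c2nnc(Cc3ccccc3)c3ccccc23)CC1`: "not active" (no number reported)

Among the measured compounds shown here, in a functional assay on A549 cells (Homo sapiens) for cytotoxicity, read by MTT assay, with a stated time of 72 h (on this read-out lower numbers stand for stronger inhibition and higher numbers for weaker inhibition), compound 1 gives 26500 nM, the only number in this small set. Compound 2 is recorded in this assay as "not active" (no number reported), without a number, so compound 1 stands alone as the single quantified point. Compound 3 `O=C(CN1CCN(c2nnc(Cc3ccncc3)c3ccccc23)CC1)Nc1ccc(F)c(F)c1` differs from compound 1 by 3,4-difluorophenyl in place of 3,4-dimethoxyphenyl on an amide-type nitrogen. For the measured compounds named here, with no measured pair to calibrate this change, the step of a 1.5-fold higher number from compound 1 to compound 3 (0.18 log units; within the scatter) is expected to stay roughly within the scatter, leaning slightly weaker. Compound 3 is therefore estimated at 40000 nM, within 12000 nM to 150000 nM.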

Compound 3, half-maximal inhibitory concentration: 3790 nM
Estimate against measurement, compound 3: 11-fold (1.02 log units) above; measured number outside the range, below it.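

In this assay there is a 7.0-fold lower number from compound 1 to compound 3 (0.84 log units; beyond the scatter) when 3,4-difluorophenyl replaces 3,4-dimethoxyphenyl on the amide-type nitrogen. The aryl group at this position therefore has a measurable influence on the read-out while the rest of compound 1 stays unchanged. Nothing given here explains the step.

The compounds shown leave open whether one ring substituent or both account for this step. They also leave open how an unsubstituted phenyl, a chlorophenyl or a pyridyl group would read on the same nitrogen.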